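From 4-fluorophenyl to 3-bromophenyl in compound 3

A few compounds are considered here, and "the series" means these few. Any claim that something is new, unique, unknown or untested is made for them only; others in the source may bear on it.

Compound 1 `CC(C)(C)c1ccc(OCCCON2C(N)=NC(N)=NC23CCSCC3)cc1`: 1 nM
Compound 2 `NC1=NC2(CCOCC2)N(OCCCOc2ccc(F)cc2)C(N)=N1`: 3280 nM

Only these two compounds have been measured so far in a functional assay on HCT-116 cells (Homo sapiens) for antiproliferative activity, read by MTT assay, with a stated time of 72 h; a higher number here means a weaker inhibitor, a lower number a stronger inhibitor. Compound 2 stands at the high end at 3280 nM, making it the weaker of the two. Compound 1 lies far lower at 1 nM, and that gap is well beyond the scatter. Going by the values given here, no measured pair isolates a single structural change, so the data give no direct guide to this one.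

Compound 3 `NC1=NC2(CCOCC2)N(OCCCOc2cccc(Br)c2)C(N)=N1` departs from compound 2 in one place: 3-bromophenyl in place of 4-fluorophenyl on an oxygen on a saturated carbon. In words, 3-bromophenyl stands in place of 4-fluorophenyl on an oxygen on a saturated carbon.

Compound 2, at 3280 nM, is at the weak end of the measured numbers, so a move toward stronger inhibition seems the likelier outcome, though this is only a tentative expectation. The expected change in this assay is a 3.6-fold lower number from compound 2 to compound 3 (0.56 log units; beyond the scatter), a moderate step toward a lower number and small beside the gap between the two measured compounds. For compound 3 the estimated value is 900 nM, with an expected range from 150 nM to 5000 nM.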

Compound 3, half-maximal inhibitory concentration: 40 nM
The estimate for compound 3 lay 23-fold (1.35 log units) above the measured number; measured number outside the range, below it.
By their numbers in this assay, from the lowest: compound 1; then compound 3; then compound 2.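

In this assay, going by these compounds alone, putting 3-bromophenyl in place of 4-fluorophenyl gives an 82-fold lower number from compound 2 to compound 3 (1.91 log units; beyond the scatter) and is the first change here that can be read on its own, since the two earlier compounds differ in more than one place. It shows that the group on the oxygen on a saturated carbon is a position where one substitution, with the rest of the structure held constant, can shift the number by a large step beyond the scatter, even though the two groups match in heavy-atom count, ring type, and their counts of hydrogen-bond donors and acceptors. No measurement available here bears on why the number falls so far.

The change alters both the halogen and its place on the ring, so this single pair cannot say whether the bromine, its position, or the two together account for the step. It also leaves open how an unsubstituted phenyl, a chlorophenyl or a pyridine ring would behave at this position, and whether the step would carry over to a compound with a different core.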